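A few compounds are considered here, and "the series" means these few. Any claim that something is new, unique, unknown or untested is made for them only; others in the source may bear on it.

Measured in an ADME assay on a cell-free system (plasma, Homo sapiens) for protein binding:
compound 1 `C[C@@H](Oc1cc2onc(CCC(=O)O)c2cc1Cl)c1ccc(Cl)cn1` gives 99.8%
compound 2 `O=C(O)CCn1c(=O)oc2cc(OCc3ccccn3)c(Cl)cc21` gives 92.6%
compound 3 `Cc1ccc([C@@H](C)Oc2cc3onc(CCC(=O)O)c3cc2Cl)nn1` gives 92.9%

Compound 2 has the highest unbound fraction of the three. Compound 3 sits within the scatter of it, while compound 1 lies far below it. Compound 4 `COCCOc1cc2oc(=O)n(CCC(=O)O)c2cc1Cl` is not yet measured in this assay. It differs from compound 2 by methoxymethyl in place of pyridin-2-yl on a saturated chain carbon bound to an oxygen on an aromatic ring. For the measured compounds named here, only one measured step touches the same place: a 36-fold higher unbound fraction from compound 1 to compound 3 (1.55 log units; beyond the scatter), which exchanged one aromatic group for another and was large. The change to compound 4 puts a group with no ring there instead, so that step gives a direction but no firm size. For compound 4 a modest rise in the unbound fraction is expected, a 1.4-fold higher unbound fraction from compound 2 to compound 4 (0.13 log units; within the scatter). The estimate for compound 4 in this assay is 90%, with a range of 82% to 95%.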

Compound 4, plasma protein binding: 70.7%
Compound 4: the middle estimate sits 2.9-fold (0.47 log units) (unbound fraction) below what was measured, and the stated range ends above it.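

In this assay, the place on a saturated chain carbon bound to an oxygen on an aromatic ring still responds when the ring there is lost: a 4.0-fold higher unbound fraction from compound 2 to compound 4 (0.60 log units; beyond the scatter) is the step, with methoxymethyl entering for pyridin-2-yl. The hydrogen-bond acceptor count stays the same across this change, so that count does not track the shift. Nothing measured here bears on the reason for the shift. Open, from the compounds shown here alone, is whether an amine or a longer ether chain at this place would move the unbound fraction further, and whether the same exchange gives a similar step on the core of compound 1.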